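Amide nitrogen substituent swap: notes toward compound 3

The compounds below may be only part of what the source reports. "The series", "measured", "known", "first", "only" and "open" are said of these compounds alone.

Measured so far:
compound 1 `COc1cc2nc(C)cc(OCC(=O)Nc3cc(C)cc(C)c3)c2cc1OC`: 4.84
compound 2 `COc1ccc(NC(=O)COc2cc(C)nc3ccc(OC)cc23)cc1`: 4.22

Both numbers come from a physicochemical assay for lipophilicity, read by HPLC, in phosphate buffer, measured as chromatographic lipophilicity, at pH 7.4; on this read-out lower numbers stand for lower lipophilicity and higher numbers for higher lipophilicity. Going by the values given here, compound 2 holds the lower of the two, and the only other measured compound, compound 1, stands above it by a gap beyond the usual scatter. Among the compounds with values here, no two measured compounds differ in a single place, so no measured step is available to calibrate the change now under consideration.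

Compound 3 `COc1ccc2nc(C)cc(OCC(=O)Nc3ccncn3)c2c1` has not yet been run in this assay. Against compound 2 it shows one change, (pyrimidin-4-yl in place of 4-methoxyphenyl on an amide-type nitrogen). The group that enters is smaller, carries two hetero atoms in its six-membered aromatic ring and brings two hydrogen-bond acceptors where the group that leaves brings one. Without a measured pair covering this change, the expectation for this assay is a drop well beyond the scatter, not a rise and not a null step.

On that basis compound 3 is expected to give 2.6, with a plausible range from 1.9 to 3.3. The step this estimate implies is a number 1.62 log units lower from compound 2 to compound 3 (beyond the scatter), an expected decrease rather than a measured one.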

Compound 3, distribution coefficient: 2.53
Compound 3: the middle estimate sits 0.07 log units above what was measured; the measured number falls inside the stated range.
By their numbers in this assay, from the lowest: compound 3; then compound 2; then compound 1.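

In this assay, going by these compounds alone, pyrimidin-4-yl in place of 4-methoxyphenyl on an amide-type nitrogen gives a number 1.69 log units lower from compound 2 to compound 3 (beyond the scatter) and supplies the only measured single-place step. The read-out therefore responds strongly to the group on this nitrogen, with the rest of the structure held constant; compound 1 could not show this, as it differs from compound 2 in more than one place. The step nevertheless covers several changes at once, since the entering group has fewer heavy atoms, hetero atoms in its ring and an additional hydrogen-bond acceptor, and nothing in the data shown bears on which of these matters or why the number falls.

Still open, going by these compounds, is how the step divides between losing the methoxy group and bringing nitrogen into the ring: plain phenyl and pyridin-4-yl on the same amide-type nitrogen would separate those two parts. Also open, on these data alone, are whether the same swap gives a step of similar size on the core of compound 1, and how an amine or a carboxylic acid on the ring at this place would read.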